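Fluoro in place of methoxy on compound 2

The source may hold more compounds than are shown below. What is called first, only, known or untested is meant among the compounds shown, and "the series" means these compounds.

- Compound 1 `COc1ccc([C@@H]2c3c(OC)cc(OC)cc3/C(=C/c3ccc(C)cc3)[C@H]2c2cc(OC)cc(OC)c2)cc1` gives > 200000 nM as a limit of the assay
- Compound 2 `COc1ccc(CSC2c3cc(OC)cc(OC)c3[C@@H](c3ccc(OC)cc3)[C@@H]2c2cc(OC)cc(OC)c2)cc1` gives 12500 nM as a measured number
- Compound 3 `COc1ccc(CSC2c3cc(OC)cc(OC)c3[C@@H](c3ccccc3)[C@@H]2c2cc(OC)cc(OC)c2)cc1` gives > 200000 nM as a limit of the assay

Going by the values given here, in a functional assay on RAW264.7 cells (Mus musculus) for inhibition, with stated times of 2 h and 24 h (a higher number here means a weaker inhibitor, a lower number a stronger inhibitor), compound 2 holds the only true number. Compound 1 and compound 3 stand at the limit of > 200000 nM in this assay, at which 2 of the 3 values shown sit, and give no number. Compound 4 `COc1ccc([C@@H]2c3c(OC)cc(OC)cc3C(SCc3ccc(F)cc3)[C@H]2c2cc(OC)cc(OC)c2)cc1` differs from compound 2 by fluoro in place of methoxy on an aromatic carbon with fluoro in place of methoxy on an aromatic carbon. Among the compounds with values here, the one measured step that bears on this is an at least 16-fold higher number from compound 2 to compound 3 (1.20 log units; beyond the scatter) in which a different methoxy gives way to hydrogen. That step is large but ends at a limit and lies elsewhere in the molecule, so it guides only loosely. A smaller move towards a higher number is expected, estimated as a 2.0-fold higher number from compound 2 to compound 4 (0.30 log units; within the scatter) for this change. The value of compound 4 is expected at 25000 nM with a range from 6000 nM to 120000 nM as the estimate.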

Compound 4, half-maximal inhibitory concentration: > 200000 nM
Compound 4: only a limit was reported (the forecaster's own chance of this, stated with the estimate: 30%); at least 8.0-fold (0.90 log units) between middle value and limit.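

The methoxy of the (4-methoxybenzyl)sulfanyl group matters in this assay, as shown by an at least 16-fold higher number from compound 2 to compound 4 (1.20 log units; beyond the scatter). Until now, only a different methoxy had been seen to matter, so a single change at either of these two places takes compound 2 from a measured number to a limit. Compound 4 gives a limit and not a number, so the true size of the step stays unknown: the limit of > 200000 nM in this assay, at which 3 of the 4 values shown sit.

On these data alone, whether any other group at this place keeps a measurable number remains open. Ethoxy, chloro, hydroxy or an amine could each answer that.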